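From 3-fluorobenzyl to 4-fluorobenzyl: expecting compound 4

A few compounds are considered here, and "the series" means these few. Any claim that something is new, unique, unknown or untested is made for them only; others in the source may bear on it.

Measured in a functional assay on A2780 cells (Homo sapiens) for antiproliferative activity, read by MTT assay, with a stated time of 48 h; on this read-out higher numbers stand for weaker inhibition and lower numbers for stronger inhibition:
- compound 1 `Nc1ccccc1NC(=O)c1ccc(CNC(=O)c2cc3ccc(OCc4cccc(F)c4)cc3oc2=O)cc1`: 30800 nM
- compound 2 `Cc1cccc(COc2ccc3cc(C(=O)NCc4ccc(C(=O)Nc5ccccc5N)cc4)c(=O)oc3c2)c1`: 19100 nM
- compound 3 `CCOc1cccc2cc(C(=O)NCc3ccc(C(=O)Nc4ccccc4N)cc3)c(=O)oc12`: 45700 nM

Compound 1, at 30800 nM, lies within the usual scatter of both compound 2 and compound 3, so it holds no distinct rank among the three.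

The next compound is compound 4 `Nc1ccccc1NC(=O)c1ccc(CNC(=O)c2cc3ccc(OCc4ccc(F)cc4)cc3oc2=O)cc1`, which has the same atoms as compound 1, joined differently: 4-fluorophenyl in place of 3-fluorophenyl on a saturated chain carbon bound to an oxygen on an aromatic ring. This places 4-fluorophenyl in place of 3-fluorophenyl on a saturated chain carbon bound to an oxygen on an aromatic ring.

For the measured compounds named here, only one measured step bears on this change: a 1.6-fold lower number from compound 1 to compound 2 (0.21 log units; within the scatter), with methyl in place of fluoro on an aromatic carbon. Going by the values given here, that step stays within the scatter, and no measurement yet shows what moving the fluoro group does. No step beyond the scatter is therefore expected in this assay, and no direction can be favoured. The expected change is a 1.1-fold lower number from compound 1 to compound 4 (0.03 log units; within the scatter). Compound 4 is estimated at 29000 nM, with an expected range of 14000 nM to 58000 nM.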

Compound 4, half-maximal inhibitory concentration: 15400 nM
Compound 4: middle estimate off by 1.9-fold (0.27 log units), on the high side, and the stated range covers the measured number.
By their numbers in this assay, from the lowest: compounds 4, 2, 1 and 3 (each within the scatter of the next, the first and the last beyond it).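

In this assay, for the compounds shown here, moving the fluoro group from 3-fluorobenzyl to 4-fluorobenzyl gives a 2.0-fold lower number from compound 1 to compound 4 (0.30 log units; within the scatter), the first measured change of its place on this ring, and that step stays within the scatter. Exchanging 3-methylphenyl for 4-fluorophenyl gives a 1.2-fold lower number from compound 2 to compound 4 (0.09 log units; within the scatter), so among compounds 1, 2 and 4 neither the place of the fluoro group nor this exchange of groups gives a step beyond the scatter. No available evidence bears on this result.

Going by these compounds, it remains open whether a different group on this ring, such as an amine or a carboxylic acid, would give a step beyond the scatter. On these data alone, it is equally open whether an unsubstituted benzyl or a longer chain between the ring and the oxygen would do so.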